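This account rests on a few compounds, and the source may have more. Where it says the series, first, only, none or still open, it means among the compounds named here.

Compound 1 `COc1ccc(NC(=O)CNC(=O)/C=C/c2ccc(O)c(OC)c2)cc1` gives 91200 nM
Compound 2 `COc1cc(/C=C/C(=O)NCC(=O)Nc2ccc(Cl)cc2)ccc1O` gives 101000 nM

Going by the values given here, in a functional assay, with a stated time of 25 min (a higher number here means a weaker inhibitor, a lower number a stronger inhibitor), compound 2 gives 101000 nM and so stands within the scatter of compound 1, the only other compound measured. Among the compounds with values here, the single measured step is a 1.1-fold higher number from compound 1 to compound 2 (0.04 log units; within the scatter) for chloro in place of methoxy on an aromatic carbon. The next compound, compound 3 `COc1cc(/C=C/C(=O)NCC(=O)Nc2ccc3[nH]ccc3c2)ccc1O`, brings a different change: 1H-indol-5-yl in place of 4-chlorophenyl on an amide-type nitrogen with 1H-indol-5-yl in place of 4-chlorophenyl on an amide-type nitrogen. Within the data shown here, only that one step bears on this change, and it bears loosely, since no measured compound carries the 1H-indol-5-yl group. Replacing chloro with methoxy left the number within the scatter, which gives a weak hint that this part of the molecule may tolerate change. No step beyond the scatter is therefore expected, and no direction can be firmly expected, although the range must stay wide. For compound 3 the estimated value is 80000 nM with an expected range from 25000 nM to 200000 nM in this assay once measured. This estimate means an expected 1.3-fold lower number from compound 2 to compound 3 (0.10 log units; within the scatter) for the change in aryl group.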

Compound 3, half-maximal inhibitory concentration: 57400 nM
Compound 3: the middle estimate sits 1.4-fold (0.14 log units) above what was measured, within the range that was stated.
By their numbers in this assay, from the lowest: compounds 3, 1 and 2 (each within the scatter of the next).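

In this assay, going by these compounds alone, the first change of ring system on the amide-type nitrogen, 1H-indol-5-yl in place of 4-chlorophenyl, gives a 1.8-fold lower number from compound 2 to compound 3 (0.25 log units; within the scatter), and 1H-indol-5-yl in place of 4-methoxyphenyl gives a 1.6-fold lower number from compound 1 to compound 3 (0.20 log units; within the scatter). The earlier compounds shown here had varied only one substituent on a six-membered aromatic ring, whereas this change enters a second, five-membered aromatic ring and a hydrogen-bond donor, and across these three compounds neither shifts the number beyond the scatter, so this position accepts a larger aryl group with no measurable gain or loss. No measurement shown here accounts for this insensitivity.

From the compounds shown here alone, all three compounds stay at similarly weak numbers, so it remains open whether any group on this nitrogen can move the number beyond the scatter, for instance a phenyl ring carrying an amine or a carboxylic acid, or a cyclohexyl group or a longer alkyl chain in place of the aryl group. The shared core is also unchanged throughout, leaving open what happens if its hydroxy or methoxy group is replaced, or if its glycine-type amide link gives way to a longer chain.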